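Aryl exchange at the chain carbon: compound 2 to compound 3

A few compounds are considered here, and "the series" means these few. Any claim that something is new, unique, unknown or untested is made for them only; others in the source may bear on it.

In a functional assay on DU-145 cells (Homo sapiens) for inhibition, read by trypan blue exclusion, with a stated time of 96 h (on this read-out higher numbers stand for weaker inhibition of growth and lower numbers for stronger inhibition of growth), compound 2 `COc1ccccc1/C=C(\C(=O)c1ccc(Cl)cc1)S(=O)(=O)Cc1ccc(C)cc1` gives 10000 nM. Compound 1 `CCOc1ccc(/C=C(\C(=O)c2ccc(Cl)cc2)S(=O)(=O)Cc2ccc(C)cc2)cc1OC` gives 10000 nM, so the two stand level at the digits shown.

Compound 3 `Cc1ccc(CS(=O)(=O)/C(=C/c2cc(C)ccc2C)C(=O)c2ccc(Cl)cc2)cc1` differs from compound 2 by 2,5-dimethylphenyl in place of 2-methoxyphenyl on a double-bonded chain carbon bound to a double-bonded chain carbon.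

For the measured compounds named here, one measured step bears on this place: no change at the digits printed from compound 1 to compound 2 (within the scatter), with 2-methoxyphenyl in place of 4-ethoxy-3-methoxyphenyl. That single step stayed within the scatter. Going by the values given here, no compound measured so far has a group free of oxygen here, so this part of the change is untested.

No shift beyond the scatter is therefore expected in either direction. The expected step is no change at the digits printed from compound 2 to compound 3 (within the scatter).

Compound 3 is estimated at 10000 nM, with an expected range of 3000 nM to 20000 nM.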

Compound 3, concentration for 50% growth inhibition: 1000 nM
Beside the measured number, compound 3's estimate is 10-fold (1.00 log units) above it; the whole stated range lies above it.
By their numbers in this assay, from the lowest: compound 3; then compounds 1 and 2 (each within the scatter of the next).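

In this assay, the aryl group on a double-bonded chain carbon bound to a double-bonded chain carbon does affect the read-out: 2,5-dimethylphenyl in place of 2-methoxyphenyl gives a 10-fold lower number from compound 2 to compound 3 (1.00 log units; beyond the scatter) and 2,5-dimethylphenyl in place of 4-ethoxy-3-methoxyphenyl gives a 10-fold lower number from compound 1 to compound 3 (1.00 log units; beyond the scatter) in the same assay. For the compounds shown here, the level pair of compound 1 and compound 2 therefore does not show that this place is insensitive to change, and 2,5-dimethylphenyl is the only group here free of oxygen. Nothing available accounts for the step.

A single exchange removes the methoxy group and adds two methyl groups, so the compounds shown do not separate these two changes. Going by these compounds, how plain phenyl, a chlorophenyl or an aminophenyl would read at this place remains open.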